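The source may hold more compounds than are shown below. What is called first, only, known or untested is meant among the compounds shown, and "the series" means these compounds.

Working notes on a cytotoxicity series.

Three compounds share one core and carry a benzyloxy-type arm that varies. Compound 1 `COc1ccccc1COc1ccnc(Nc2ccc(C#N)cc2)n1` gives 8900 nM in an ADME assay on MT4 cells (Homo sapiens) for cytotoxicity, read by MTT assay, with a stated time of 5 days; on this read-out lower numbers stand for higher toxicity in this test and higher numbers for lower toxicity in this test. Compound 2 `COc1cccc(COc2ccnc(Nc3ccc(C#N)cc3)n2)c1` gives 118000 nM in this assay, and compound 3 `N#Cc1ccc(Nc2nccc(OCc3ccccc3C(F)(F)F)n2)cc1` gives 173000 nM in this assay.

The cores of compound 1 and compound 2 differ by 3-methoxyphenyl in place of 2-methoxyphenyl on a saturated chain carbon bound to an oxygen on an aromatic ring, and this change makes the step of a 13-fold higher number from compound 1 to compound 2 (1.12 log units; beyond the scatter). The change trifluoromethyl in place of methoxy on an aromatic carbon makes the step of a 19-fold higher number from compound 1 to compound 3 (1.29 log units; beyond the scatter). The values of compound 2 and compound 3 sit within the scatter of each other.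

Compound 4 `N#Cc1ccc(Nc2nccc(OCc3cccc(C(F)(F)F)c3)n2)cc1` is not yet measured. It differs from compound 2 by trifluoromethyl in place of methoxy on an aromatic carbon. Among the measured compounds shown here, this is the same kind of change as the one from compound 1 to compound 3, though the place is not the same: in compound 4 the group sits meta to a large group, in compound 3 ortho to a large group.

For compound 4 the step of a 1.5-fold higher number from compound 2 to compound 4 (0.18 log units; within the scatter) in this assay is expected to be smaller than a 19-fold higher number from compound 1 to compound 3 (1.29 log units; beyond the scatter), because compound 2 already gives 118000 nM and compound 3 gives 173000 nM, so little room appears left. Compound 4 is estimated at 180000 nM, between 80000 nM and 400000 nM.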

Compound 4, half-maximal cytotoxic concentration: 118000 nM
For compound 4 the middle estimate is 1.5-fold (0.18 log units) above the measured one; measured number inside the range.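

In this assay, trifluoromethyl in place of methoxy gives no change at the digits printed from compound 2 to compound 4 (within the scatter), so the size of the step on one pair does not carry over to the other: the same change on two cores in this assay, a 19-fold higher number (1.29 log units; beyond the scatter) from compound 1 to compound 3 and no change at the digits printed (within the scatter) from compound 2 to compound 4, 19-fold (1.29 log units) apart, beyond the scatter of two such steps

This shows that, in this series, the step seen on one core cannot be taken as a forecast for the other, and that the large step is so far seen only where compound 1, at 8900 nM, is the starting point. It does not show why the two steps part, since the two pairs differ in where the group sits as well as in the arm around it, and two pairs cannot separate these or support a rule for other cores.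

The compounds shown leave open how a chlorine or a methyl in the same place on the arm would read in this assay. Also open, from the compounds shown here alone, is whether the change behaves in the same way on a core carrying an amine or a carboxylic acid in place of the nitrile.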